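Moving the phenol hydroxyl around a shared core

The source may report more compounds than this note shows. Statements on the series, on what has been measured and on what is new or still open speak of the compounds shown alone.

compound 1, `Oc1ccc(-c2cc(-c3ccccc3O)nc(-c3ccccc3O)c2)cc1`: > 50000 nM
compound 2, `Oc1ccc(-c2cc(-c3cccc(O)c3)nc(-c3ccccc3O)c2)cc1`: 3420 nM

In a functional assay on DU-145 cells (Homo sapiens) for cytotoxicity, read by CCK-8 assay, with a stated time of 4 days (on this read-out lower numbers stand for stronger inhibition and higher numbers for weaker inhibition), compound 1 reaches only the assay limit, > 50000 nM. Compound 2 gives 3420 nM, the only number shown, so it stands alone among the measured values. For the measured compounds named here, the single measured step, an at least 14-fold lower number from compound 1 to compound 2 (1.16 log units; beyond the scatter), is the only guide. Compound 3, `Oc1ccc(-c2cc(-c3ccc(O)cc3)nc(-c3ccccc3O)c2)cc1`, is not yet measured; it differs from compound 2 by 4-hydroxyphenyl in place of 3-hydroxyphenyl on an aromatic carbon. Going by the values given here, with no second step to weigh, a change within the scatter or a modest gain is anticipated. Compound 3 is expected near 2500 nM, with a range from 600 nM to 12000 nM. This expected step, a 1.4-fold lower number from compound 2 to compound 3 (0.14 log units; within the scatter), is small.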

Compound 3, half-maximal inhibitory concentration: > 50000 nM
Compound 3 gave a limit, no number; the forecaster's own chance of this, stated with the estimate: 5%; at least 20-fold (1.30 log units) between middle value and limit.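

In this assay, the ring position next to the ring nitrogen proves sensitive to where the hydroxyl sits on the attached phenyl group, with 4-hydroxyphenyl giving an at least 14-fold higher number from compound 2 to compound 3 (1.16 log units; beyond the scatter). Compound 2, with its 3-hydroxyphenyl group, is now the only one of the three with a readable number, since both the 2-hydroxyphenyl and the 4-hydroxyphenyl group end at a limit. The step between compound 1 and compound 3 cannot be read: the limit of > 50000 nM in this assay, at which 2 of the 3 values shown sit.

On these data alone, how far those two compounds lie beyond the limit remains open. So does whether an amine or a methoxy group in place of the hydroxyl of the 3-hydroxyphenyl group would keep a measurable number.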